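Hydroxy to methoxy on the oxime ether side chain

The source may report more compounds than this note shows. Statements on the series, on what has been measured and on what is new or still open speak of the compounds shown alone.

Compound 1 `O=c1cc(-c2ccccc2)oc2cc(OC/C(=N/O)c3ccc(F)cc3)ccc12`, compound 2 `O=c1c(-c2ccccc2)coc2cc(OC/C(=N/O)c3ccccc3)ccc12` and compound 3 `CO/N=C(/COc1ccc2c(=O)cc(-c3ccccc3)oc2c1)c1ccc(F)cc1` were run in a functional assay on SK-HEP1 cells (Homo sapiens) for antiproliferative activity; a higher number here means a weaker inhibitor of growth, a lower number a stronger inhibitor of growth. Compound 1 gives 2300000 nM, compound 2 gives 6400000 nM and compound 3 gives 3300000 nM. Compound 3 differs from compound 1 by one change (methyl in place of hydrogen on an oxygen), and the step of a 1.4-fold higher number from compound 1 to compound 3 (0.16 log units; within the scatter). The difference between the cores of compound 1 and compound 2 is not broken down here; their values in this assay lie beyond the scatter of each other. Compound 4 `CO/N=C(/COc1ccc2c(=O)c(-c3ccccc3)coc2c1)c1ccccc1` has not been measured; it differs from compound 2 by the same change (methyl in place of hydrogen on an oxygen), at a place described in the same words. The expected step of a 1.4-fold higher number from compound 2 to compound 4 (0.15 log units; within the scatter) rests on the measured step of a 1.4-fold higher number from compound 1 to compound 3 (0.16 log units; within the scatter), which stayed within the scatter. In this assay compound 4 is therefore estimated at 9000000 nM, with a range from 4000000 nM to 20000000 nM.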

Compound 4, concentration for 50% growth inhibition: 7400000 nM
Estimate against measurement, compound 4: 1.2-fold (0.09 log units) above; the measured number falls inside the stated range.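

In this assay, hydroxy to methoxy on the core of compound 2 gives a 1.2-fold higher number from compound 2 to compound 4 (0.06 log units; within the scatter). The change behaves alike on the two cores, with no difference that can be told apart from scatter: the same change on two cores in this assay, a 1.4-fold higher number (0.16 log units; within the scatter) from compound 1 to compound 3 and a 1.2-fold higher number (0.06 log units; within the scatter) from compound 2 to compound 4, 1.2-fold (0.09 log units) apart, within the scatter of two such steps. For the compounds shown here, this shows only that the change left the number essentially unmoved on these two cores; it does not show that hydroxy and methoxy are interchangeable on any other core, or in any other assay.

From the compounds shown here alone, whether a longer chain on that oxygen, such as ethyl or butyl, would also leave the number unmoved stays open. So does the outcome for a chain on that oxygen ending in an amine or a carboxylic acid.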